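The compounds below may be only part of what the source reports. "The series", "measured", "known", "first", "only" and "open" are said of these compounds alone.

Compound 1 `CCn1c(C(=O)NCCN(C)C)ccc1C(CC)(CC)c1ccc(OCCC(O)(CC)CC)c(C)c1` is tested in a functional assay on Caco-2 cells (Homo sapiens) for antiproliferative activity, read by MTT assay, with a stated time of 48 h (on this read-out higher numbers stand for weaker inhibition and lower numbers for stronger inhibition), where compound 1 gives 1140 nM. Of the two plain numbers available, this is the lowest; the nearest is compound 3 `CCOC(=O)CN(C)C(=O)c1ccc(C(CC)(CC)c2ccc(OCCC(O)(CC)CC)c(C)c2)n1CC`, which in this assay gives 30300 nM. Compound 2 `CCn1c(C(=O)Nc2cccc(C(F)(F)F)c2)ccc1C(CC)(CC)c1ccc(OCCC(O)(CC)CC)c(C)c1` reaches only a limit of this assay, reported as > 50000 nM (the limit of > 50000 nM in this assay, at which 1 of the 3 values shown sits). Compound 4 `CCn1c(C(=O)NC(C)C(=O)O)ccc1C(CC)(CC)c1ccc(OCCC(O)(CC)CC)c(C)c1` has not yet been measured; it differs from compound 1 in one place: 1-carboxyethyl in place of 2-(dimethylamino)ethyl on an amide-type nitrogen. Two measured steps either swap the 2-(dimethylamino)ethyl group on the amide-type nitrogen for another group or replace the whole (2-(dimethylamino)ethyl)amino part: an at least 43-fold higher number from compound 1 to compound 2 (1.64 log units; beyond the scatter) and a 27-fold higher number from compound 1 to compound 3 (1.42 log units; beyond the scatter). Both point the same way, toward weaker inhibition by a large margin. Compound 4 likewise loses the 2-(dimethylamino)ethyl group, so a similar large step toward weaker inhibition is expected: a 22-fold higher number from compound 1 to compound 4 (1.34 log units; beyond the scatter). Compound 4 is therefore estimated at 25000 nM, with an expected range from 6000 nM to 80000 nM, and a fair chance that only a limit is reported.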

Compound 4, half-maximal inhibitory concentration: 46500 nM
The estimate for compound 4 lay 1.9-fold (0.27 log units) below the measured number; the range from low to high includes it.
By their numbers in this assay, from the lowest: compound 1; then compounds 3 and 4 (each within the scatter of the next). At a limit, above all of these: compound 2.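

Compound 4 keeps a chain of the same heavy-atom count on the amide-type nitrogen, with no ring, unlike the 3-(trifluoromethyl)phenyl group of compound 2, yet the large loss remains in this assay: a 41-fold higher number from compound 1 to compound 4 (1.61 log units; beyond the scatter). Chain size alone therefore does not preserve the activity of compound 1, the only one of these four compounds that carries a dimethylamino group. The two replacements compared next cannot be told apart: a 1.5-fold higher number from compound 3 to compound 4 (0.19 log units; within the scatter). One further step cannot be read: an at least 1.0-fold lower number from compound 2 to compound 4 (0.03 log units; that floor lies within the scatter). The value of compound 2 is only a limit: the limit of > 50000 nM in this assay, at which 1 of the 4 values shown sits.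

On these data alone, it remains open whether the amine itself matters or also its distance from the amide, which a 3-(dimethylamino)propyl chain or a primary amine on the same ethyl chain could test. A plain alkyl chain ending in neither an amine nor a carboxylic acid would show whether the carboxylic acid of compound 4 contributes anything beyond the loss of the amine.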